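Methyl to trifluoromethyl: an expectation for compound 4

This account rests on a few compounds, and the source may have more. Where it says the series, first, only, none or still open, it means among the compounds named here.

Compound 1 `C#CCNC1CCc2c(SCCc3ccc(C)cc3)cccc21`: in an ADME assay on isolated protein for inhibition of Amine oxidase [flavin-containing] B (Homo sapiens) (on this read-out lower numbers stand for stronger inhibition and higher numbers for weaker inhibition), compound 1 gives 4520 nM.
Compound 2 `C#CCNC1CCc2c(SCCc3cccc(Br)c3)cccc21`: in this assay compound 2 gives 620 nM.
Compound 3 `C#CCNC1CCc2c(SCCc3cccc(Cl)c3)cccc21`: in this assay compound 3 gives "not determined" (no result reported), that is, no result is reported for it.

Compound 1 stands highest of the two numbers, and its nearest neighbour is compound 2, reached by a 7.3-fold lower number from compound 1 to compound 2 (0.86 log units; beyond the scatter). Compound 4 `C#CCNC1CCc2c(SCCc3ccc(C(F)(F)F)cc3)cccc21` differs from compound 1 by trifluoromethyl in place of methyl on an aromatic carbon. Going by the values given here, no measured step changes only this group: the step from compound 1 to compound 2 alters both which group is present and where it sits, so it bears on compound 4 only loosely. A step of modest size at most is expected, more likely toward a lower number than a higher one. Compound 4 is therefore expected to show a 1.8-fold lower number from compound 1 to compound 4 (0.26 log units; within the scatter), with an estimate of 2500 nM in a range from 600 nM to 9000 nM.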

Compound 4, half-maximal inhibitory concentration: 8780 nM
Beside the measured number, compound 4's estimate is 3.5-fold (0.55 log units) below it, and the stated range covers the measured number.
By their numbers in this assay, from the lowest: compound 2; then compounds 1 and 4 (each within the scatter of the next).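

Trifluoromethyl in place of methyl on an aromatic carbon, para to a large group, gives a 1.9-fold higher number from compound 1 to compound 4 (0.29 log units; within the scatter). Going by these compounds alone, this is the first measured change confined to this one place, and in this assay it does not separate the two compounds, although the entering group holds more heavy atoms. Nothing available bears on why this is so.

The compounds shown leave open whether a methoxy group or an amine at this same place would also stay within the scatter of compound 1. On these data alone, it also remains open how trifluoromethyl would behave where compound 2 carries its bromine.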